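Fluoro for chloro on the aryl ring: estimate for compound 4

The compounds below may be only part of what the source reports. "The series", "measured", "known", "first", "only" and "open" are said of these compounds alone.

Measured compounds:
compound 1 `COCC(C(=O)N1CCN(c2cccc(C(F)(F)F)c2)CC1)N1C(=O)CCC1=O`: 0%
compound 2 `CC(C(=O)N1CCN(c2ccccc2)CC1)N1C(=O)CCC1=O`: 0%
compound 3 `CC(C(=O)N1CCN(c2ccc(Cl)cc2)CC1)N1C(=O)CCC1=O`: 0%

In a functional assay on the whole organism (strain Swiss) with Mus musculus as the target, in the maximal electroshock model, with a stated time of 2 h, at a dose of 100 mg/kg by the intraperitoneal route (a higher number here means a stronger effect of the compound at the dose given, a lower number a weaker effect), compound 1 gives 0%, compound 2 gives 0% and compound 3 gives 0%. Compound 3 therefore stands level with compounds 1 and 2 at the digits shown; no measured compound is separated from another beyond the scatter. For the measured compounds named here, the only single-point step among measured compounds is no change at the digits printed from compound 2 to compound 3 (within the scatter). Compound 4 `CC(C(=O)N1CCN(c2ccc(F)cc2)CC1)N1C(=O)CCC1=O` is not yet measured; it differs from compound 3 as follows: fluoro in place of chloro on an aromatic carbon. Going by the values given here, the step from compound 2 to compound 3 is the one that bears on this halogen position, and it showed nothing beyond the scatter; no measured step exchanges one halogen for another. No step beyond the scatter is therefore expected in this assay, and the expected step is no change at the digits printed from compound 3 to compound 4 (within the scatter). For compound 4 the estimate in this assay is 0%, with a range from 0% to 10%.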

Compound 4, a percentage reported as activity, at one dose (the size of the read-out at that dose, not a potency): 0%
For compound 4 middle estimate and measured number coincide at the digits printed; the range from low to high includes it.
By their numbers in this assay, from the lowest: compounds 1, 2, 3 and 4 (each within the scatter of the next).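

In this assay, fluoro in place of chloro on the aromatic carbon gives no change at the digits printed from compound 3 to compound 4 (within the scatter), and fluoro in place of hydrogen gives no change at the digits printed from compound 2 to compound 4 (within the scatter). Hydrogen, chloro and fluoro at this position are therefore not told apart at this dose, and the halogen exchange adds no read-out to the series. No further data bear on this result. From the compounds shown here alone, it remains open whether an amine or a carboxylic acid on the aryl ring, or a longer chain on the shared core, would give any read-out in this assay.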